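A few compounds are considered here, and "the series" means these few. Any claim that something is new, unique, unknown or untested is made for them only; others in the source may bear on it.

Compound 1 `CNC(=O)c1cc(Oc2ccc(NC(=O)c3cc(-c4ccc(F)cc4)ncn3)cc2F)ccn1` was tested in a functional assay on A549 cells (Homo sapiens) for cytotoxicity, read by MTT assay, with a stated time of 72 h; on this read-out lower numbers stand for stronger inhibition and higher numbers for weaker inhibition. In this assay compound 1 gives > 100000 nM, which is a limit of the assay rather than a number. Compound 2 `CNC(=O)c1cc(Oc2ccc(NC(=O)c3cc(-c4ccc(Cl)cc4)ncn3)cc2)ccn1` also reaches only a limit, giving > 100000 nM. Compound 3 `CNC(=O)c1cc(Oc2ccc(NC(=O)c3nccc(-c4ccccc4)n3)cc2)ccn1` gives 26200 nM in this assay. Compound 1 therefore sits at the limit of > 100000 nM in this assay, at which 2 of the 3 values shown sit. The next compound is compound 4 `CNC(=O)c1cc(Oc2ccc(NC(=O)c3cc(-c4ccc(OC)cc4)ncn3)cc2F)ccn1`, which differs from compound 1 by methoxy in place of fluoro on an aromatic carbon. Within the data shown here, no step between two measured compounds is at hand, so nothing shows how large such a change is in this assay; the expectation is a step no larger than the scatter. Compound 4 is expected to give 90000 nM, between 30000 nM and 250000 nM, an expected step of an at least 1.1-fold lower number from compound 1 to compound 4 (0.04 log units; that floor lies within the scatter).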

Compound 4, half-maximal inhibitory concentration: 34500 nM
The estimate for compound 4 lay 2.6-fold (0.42 log units) above the measured number, within the range that was stated.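

Going from 4-fluorophenyl to 4-methoxyphenyl gives an at least 2.8-fold lower number from compound 1 to compound 4 (0.46 log units; beyond the scatter) in this assay, so the number in this assay does respond to a change of group at this position. Compound 1 stands at a limit rather than a number, so the step has a floor but no known full size, and that limit is shared with another compound: the limit of > 100000 nM in this assay, at which 2 of the 4 values shown sit.

The compounds shown leave open whether an amine or a longer chain such as ethoxy at this position would lower the number further. As far as these compounds go, whether methoxy has the same effect on other cores also remains open.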